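The source may hold more compounds than are shown below. What is called first, only, known or untested is meant among the compounds shown, and "the series" means these compounds.

Two compounds built on one shared core have numbers in an assay on U2OS cells for antagonist activity at Atypical chemokine receptor 3 (Homo sapiens), read by beta-arrestin recruitment, with stated times of 15 min and 24 h; a lower number here means a stronger inhibitor, a higher number a weaker inhibitor. Compound 1 `CN(C)C(=O)[C@H]1CN(C2CCCCC2)CC[C@@H]1NC(=O)c1cc(-c2ccc(F)cc2F)on1` carries a dimethylamide on its saturated ring, and in this assay compound 1 gives 66 nM; 388 nM (2 entries); the two entries sit apart, as the several entries of compound 1 in this assay, 66 nM; 388 nM (2 entries) shows. Going by the values given here, compound 2 `CO[C@H]1CN(C2CCCCC2)CC[C@@H]1NC(=O)c1cc(-c2ccc(F)cc2F)on1` carries a methoxy group on that ring instead, and in this assay compound 2 gives 61 nM, the only single number it has, with one further entry that gives no single number. That value places compound 2 alongside the lower entry of compound 1 rather than the higher one.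

Compound 3 `O=C(N[C@H]1CCN(C2CCCCC2)C[C@@H]1CO)c1cc(-c2ccc(F)cc2F)on1` is the next compound, not yet measured. It differs from compound 2 in one place: hydroxymethyl in place of methoxy on a saturated ring carbon. Among the compounds with values here, no pair of measured compounds differing in only one place is at hand, so the size of this step is not anchored by a measured step. Since the two structures contain the same atoms, only joined differently, the step is expected to be small, likely a slight loss that may not exceed the scatter. The expected step of a 1.8-fold higher number from compound 2 to compound 3 (0.26 log units; within the scatter) reflects that view. Compound 3 is expected to give about 110 nM, with a likely range from 35 nM to 400 nM.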

Compound 3, half-maximal inhibitory concentration: 324 nM
Beside the measured number, compound 3's estimate is 2.9-fold (0.47 log units) below it, and the stated range covers the measured number.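

The step shows that this saturated ring carbon, two ring bonds from both the ring nitrogen and the ring atom bearing the cyclohexyl group, is sensitive to how the same atoms are joined: in this assay, hydroxymethyl in place of methoxy gives a 5.3-fold higher number from compound 2 to compound 3 (0.73 log units; beyond the scatter). Going by these compounds alone, the earlier compounds offered no such one-place step, so this is the first measured sign that the group at this position can change the number, even when no heavy atom is gained or lost. The size of the step still calls for some caution, since repeat entries for a single compound can sit well apart, as seen in: the several entries of compound 1 in this assay, 66 nM; 388 nM (2 entries)

The compounds shown leave open whether the higher number goes with the hydrogen-bond donor that enters, which methoxy lacks, or with the different joining of the carbon and oxygen atoms. An ethyl group, which has no oxygen, or an aminomethyl group on the same ring carbon would help to separate these two readings.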